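The compounds below may be only part of what the source reports. "The series", "measured", "known", "first", "only" and "open" are said of these compounds alone.

The compounds measured so far:
Compound 1, `CCCN(CCC)c1cc(C(F)(F)F)ccc1CNC(=O)C(C)c1ccc(NS(C)(=O)=O)c(F)c1`, gives 0.3 nM in an assay on CHO cells for antagonist activity at transient receptor potential cation channel subfamily V member 1 (Homo sapiens), read by FLIPR; a lower number here means a stronger inhibitor, a higher number a weaker inhibitor.
Compound 2, `CC(C(=O)NCc1ccc(C(F)(F)F)cc1N1CCCCCCC1)c1ccc(NS(C)(=O)=O)c(F)c1`, gives 2.8 nM in this assay.
Compound 3, `CCC1CCN(c2cc(C(F)(F)F)ccc2CNC(=O)C(C)c2ccc(NS(C)(=O)=O)c(F)c2)CC1`, gives 0.7 nM in this assay.

Compound 3 stands second highest of the three numbers. Compound 1 lies nearest, with the step of a 2.3-fold higher number from compound 1 to compound 3 (0.37 log units; beyond the scatter), and compound 2 furthest, with the step of a 4.0-fold lower number from compound 2 to compound 3 (0.60 log units; beyond the scatter). All three share the same core and differ only in the amine on an aromatic carbon; the step of a 9.3-fold higher number from compound 1 to compound 2 (0.97 log units; beyond the scatter) shows how far that group alone can move the number.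

Compound 4, `CC(C(=O)NCc1ccc(C(F)(F)F)cc1N1CCC(C(F)(F)F)CC1)c1ccc(NS(C)(=O)=O)c(F)c1`, takes one step from compound 3: trifluoromethyl in place of ethyl on a saturated ring carbon. For the measured compounds named here, no measured pair alters the substituent on the six-membered ring, so this step has no direct precedent. Going by the values given here, the steps that bear on it are the two that reshape the amine itself, a 2.3-fold higher number from compound 1 to compound 3 (0.37 log units; beyond the scatter) and a 4.0-fold lower number from compound 2 to compound 3 (0.60 log units; beyond the scatter), both modest. The ring is kept and only its substituent changes, so a step within the scatter or slightly weaker is expected; the expected step is a 1.4-fold higher number from compound 3 to compound 4 (0.15 log units; within the scatter). Compound 4 is estimated at 1 nM in this assay, with a range from 0.3 nM to 3 nM.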

Compound 4, inhibition constant: 0.4 nM
Compound 4: the middle estimate sits 2.5-fold (0.40 log units) above what was measured; low and high end bracket the measured number.
By their numbers in this assay, from the lowest: compounds 1, 4 and 3 (each within the scatter of the next, the first and the last beyond it); then compound 2.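

In this assay, the saturated ring carbon three ring bonds from the ring nitrogen accepts trifluoromethyl, with four heavy atoms, in place of ethyl, with two, and the step (a 1.8-fold lower number from compound 3 to compound 4 (0.24 log units; within the scatter)) shows no change that can be told from the scatter. With this new substituent, the six-membered ring also stands within the scatter of the open-chain dipropylamino group (a 1.3-fold higher number from compound 1 to compound 4 (0.12 log units; within the scatter)), while the eight-membered ring remains apart from it (a 7.0-fold lower number from compound 2 to compound 4 (0.85 log units; beyond the scatter)), so the gap between the six- and eight-membered rings seen with compound 3 also appears with compound 4. Nothing at hand explains why this ring carbon accepts either group.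

What the compounds shown leave open is whether this ring carbon would accept a hydroxyl, a primary amine or a carboxylic acid as it accepts ethyl and trifluoromethyl, since both groups tested there carry no hydrogen-bond donors or acceptors and no net charge. On these data alone, it is also open whether a single fluorine or a longer chain such as butyl would keep the number in the same range, or whether trifluoromethyl would behave alike on the eight-membered ring.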